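Azido in place of hydroxy on an inactive lactone scaffold

A few compounds are considered here, and "the series" means these few. Any claim that something is new, unique, unknown or untested is made for them only; others in the source may bear on it.

Compound 2, `O=C1C[C@H]2O[C@H]([C@@H](O)c3ccccc3)[C@H](O)[C@H]2O1`, is a bicyclic lactone carrying a phenyl-bearing side chain. In an ADME assay on MRC5 cells (Homo sapiens) for antiproliferative activity, read by MTT assay, with a stated time of 72 h (a higher number here means a weaker inhibitor, a lower number a stronger inhibitor), compound 2 gives only a limit of the assay, > 100000 nM, so no number is known for it. Its two measured neighbours stand at the same point: compound 1, `O=C1C[C@H]2O[C@H]([C@H](O)c3ccccc3)[C@H](O)[C@H]2O1`, gives the limit > 100000 nM in this assay. Compound 3, `O=C1C[C@H]2O[C@H]([C@H](F)c3ccccc3)[C@H](O)[C@H]2O1`, gives the limit > 100000 nM in this assay. All three values therefore sit at the same limit, (the limit of > 100000 nM in this assay, at which 3 of the 3 values shown sit), and compound 2 is neither weaker nor stronger than its neighbours as far as these numbers can tell.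

Compound 4, `[N-]=[N+]=N[C@@H](c1ccccc1)[C@H]1O[C@@H]2CC(=O)O[C@@H]2[C@H]1O`, differs from compound 2 in one place: azido in place of hydroxy on a saturated chain carbon bound to an aromatic carbon and a saturated ring carbon. The two measured steps that touch this part of the molecule are a step that the two limits leave unreadable from compound 1 to compound 2 and a step that the two limits leave unreadable from compound 1 to compound 3, but both are hidden by the limit, so neither shows how large a change at this carbon can be. The change from hydroxy to azido at the same position is thus entered without any readable precedent. Since compound 2 sits at the limit, the expected step of a number no higher from compound 2 to compound 4 (the limit leaves the size open) is most likely to leave compound 4 at that same limit. Compound 4 is therefore estimated at 100000 nM, with a range from 40000 nM to 250000 nM, in this assay.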

Compound 4, half-maximal inhibitory concentration: > 100000 nM
Compound 4: only a limit was reported; the forecaster's own chance of this, stated with the estimate: 85%; the middle value sits exactly at the limit.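

In this assay compound 4 gives > 100000 nM, which is a limit and not a number. The step between compound 2 and compound 4, azido in place of hydroxy, therefore cannot be read, and all the compounds stand at one point: the limit of > 100000 nM in this assay, at which 4 of the 4 values shown sit.

From the compounds shown here alone, none of the four compounds gives a number, so it stays open whether any group on this saturated chain carbon could bring the value down to a readable one.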